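Replacing 1-(methoxymethyl)ethyl with 3,3,3-trifluoropropyl on an amine nitrogen

The source may report more compounds than this note shows. Statements on the series, on what has been measured and on what is new or still open speak of the compounds shown alone.

Measured in an ADME assay on microsomes from liver (Homo sapiens) for metabolic stability; on this read-out lower numbers stand for slow clearance and higher numbers for fast clearance:
- Compound 1 `COCCCNCc1cc([C@]2(C)CCSC(N)=N2)c(F)cc1F`: < 8 mL/min/kg (a limit of the assay)
- Compound 2 `COC[C@@H](C)NCc1cc([C@]2(C)CCSC(N)=N2)c(F)cc1F`: < 8 mL/min/kg (a limit of the assay)
- Compound 3 `C[C@@]1(c2cc(CNCCC(F)(F)F)c(F)cc2F)CCSC(N)=N1`: not yet measured

In this assay compound 2 gives < 8 mL/min/kg, which is a limit and not a number. The same holds for the other measured compound: the limit of < 8 mL/min/kg in this assay, at which 2 of the 2 values shown sit.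

Compound 3 carries 3,3,3-trifluoropropyl in place of 1-(methoxymethyl)ethyl on an amine nitrogen. Among the compounds with values here, the one measured step at this nitrogen is a step that the two limits leave unreadable from compound 1 to compound 2, so it offers no size to carry over. Within the data shown here, no measured compound carries 3,3,3-trifluoropropyl. No step beyond the usual scatter is therefore expected in this assay, and no direction can be firmly expected. The expected step is a number no lower from compound 2 to compound 3 (the limit leaves the size open). For compound 3 the estimated clearance is 8 mL/min/kg, with an expected range from 5 mL/min/kg to 16 mL/min/kg.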

Compound 3, clearance: 9.3 mL/min/kg
Compound 3: the middle estimate sits 1.2-fold (0.07 log units) below what was measured, and the stated range covers the measured number.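

In this assay, within the data shown here, compound 3 gives 9.3 mL/min/kg, the only value at this amine nitrogen that is a number and not a limit. With 3,3,3-trifluoropropyl on the nitrogen, the change reads as an at least 1.1-fold higher number from compound 2 to compound 3 (0.06 log units; that floor lies within the scatter), and as an at least 1.1-fold higher number from compound 1 to compound 3 (0.06 log units; that floor lies within the scatter); both are floors, so the true size of each step stays unread. Compounds 1 and 2 each stand at a limit of the assay and not at a number: the limit of < 8 mL/min/kg in this assay, at which 2 of the 3 values shown sit.

The compounds shown leave open where compounds 1 and 2 really lie, and so whether the step to 3,3,3-trifluoropropyl moves clearance beyond the scatter at all. They also leave open how a plain propyl chain or a longer fluorinated chain such as 4,4,4-trifluorobutyl would read on this nitrogen.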